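This account rests on a few compounds, and the source may have more. Where it says the series, first, only, none or still open, it means among the compounds named here.

The shared core of these compounds carries an oxygen on an aromatic ring, and the group hanging from that oxygen is what changes. Compound 1 `CC1CCCCC1Oc1cccc2ccc(N)nc12` bears a 2-methylcyclohexyl there, and in an assay on cells with melanin-concentrating hormone receptor 1 (Homo sapiens) as the target, read by radioligand binding (on this read-out lower numbers stand for stronger inhibition and higher numbers for weaker inhibition), compound 1 gives 32 nM. Going by the values given here, compound 2 `CCCC(C)Oc1cccc2ccc(N)nc12` instead bears an open 1-methylbutyl chain, and in this assay compound 2 gives 105 nM, the higher of the two numbers measured so far, so its inhibition is weaker than that of compound 1 by a gap that lies beyond the usual scatter.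

Compound 3 `Nc1ccc2cccc(OC3CCC3)c2n1` has not yet been measured. The change from compound 2 is cyclobutyl in place of 1-methylbutyl on an oxygen on an aromatic ring. Among the compounds with values here, no step between two measured compounds matches this exchange, so the expectation rests only on what compounds 1 and 2 show. Within the data shown here, because compound 1 with its ring gives 32 nM, a ring on the oxygen seems compatible with strong inhibition, though only a single pair is available and the ring here is smaller. A modest move toward a lower number, within the scatter, is expected from compound 2 to compound 3, a 1.5-fold lower number from compound 2 to compound 3 (0.18 log units; within the scatter). Compound 3 is therefore estimated at 70 nM, in a range from 20 nM to 250 nM.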

Compound 3, half-maximal inhibitory concentration: > 2000 nM
Compound 3: a limit, no number (the forecaster's own chance of this, stated with the estimate: 5%); middle value at least 28-fold (1.45 log units) from the limit.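

In this assay compound 3 gives > 2000 nM, which is a limit of the assay and not a number. Exchanging 1-methylbutyl for cyclobutyl on this oxygen brings an at least 19-fold higher number from compound 2 to compound 3 (1.27 log units; beyond the scatter), so a change of only 5 heavy atoms to 4 can separate a measurable value from one that runs off the assay's range. A ring on the oxygen therefore does not by itself go with strong inhibition: compound 1, with its 2-methylcyclohexyl, gives 32 nM in this assay, yet compound 3 also carries a ring and falls far behind compound 2, which has none.

On these data alone, how far the true value of compound 3 lies from that of compound 2 stays unknown, as the data offer only this: the limit of > 2000 nM in this assay, at which 1 of the 3 values shown sits. As far as these compounds go, it also remains open whether a cyclopentyl ring or a straight butyl chain on the same oxygen would stay close to compound 1 and compound 2 or fall away as compound 3 does, so the small set cannot yet tell whether ring size or some other feature of the group decides the outcome.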